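A few compounds are considered here, and "the series" means these few. Any claim that something is new, unique, unknown or untested is made for them only; others in the source may bear on it.

Measured so far: compound 1 `CC1=C(N2CC2)C(=O)C(CCCOC(N)=O)=C(N2CC2)C1=O` gives 5.93 in a functional assay on L1210 cells (Mus musculus), with a stated time of 12 days; a lower number here means a less potent compound, a higher number a more potent compound, by a factor of ten per unit of this negative logarithm; compound 2 `COCCC1=C(N2CC2)C(=O)C(C)=C(N2CC2)C1=O` gives 5.42; compound 3 `CC1=C(N2CC2)C(=O)C(C(C)C)=C(N2CC2)C1=O` gives 5.21.

Compound 2 stands second highest of these three numbers: compound 3 is nearest, a number 0.21 log units lower from compound 2 to compound 3 (within the scatter), while compound 1 is furthest, a number 0.51 log units lower from compound 1 to compound 2 (beyond the scatter). The unmeasured compound 4 `COCCC1=C(N2CC2)C(=O)C(CCOC)=C(N2CC2)C1=O` differs from compound 2 by methoxymethyl in place of hydrogen on a saturated chain carbon bound to a double-bonded ring carbon, so that the methyl of compound 2 becomes a second 2-methoxyethyl. Within the data shown here, no measured step replaces a methyl with a 2-methoxyethyl, and the single step touching a 2-methoxyethyl, a number 0.21 log units lower from compound 2 to compound 3 (within the scatter), lies within the scatter. The expected step is therefore small, a number 0.08 log units higher from compound 2 to compound 4 (within the scatter), with no clear direction. Compound 4 is estimated at 5.5, from 5.1 to 5.9.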

Compound 4, logarithm of the reciprocal of the active concentration, log(1/C): 5.31
Estimate against measurement, compound 4: 0.19 log units above; low and high end bracket the measured number.
By their numbers in this assay, from the lowest: compounds 3, 4 and 2 (each within the scatter of the next); then compound 1.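

In this assay, among these compounds, the step from a methyl to a second 2-methoxyethyl is a number 0.11 log units lower from compound 2 to compound 4 (within the scatter), the first measured change at this position of compound 2. Adding methoxymethyl in place of hydrogen on the saturated chain carbon therefore leaves the two compounds indistinguishable in this assay. No supporting measurement bears on this result. Going by these compounds, whether an amine or a carboxylic acid in place of the methoxymethyl, or a longer chain, would give a step beyond the scatter stays open.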